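Benzylic alcohol in place of the sulfonamide on the anilide core

A few compounds are considered here, and "the series" means these few. Any claim that something is new, unique, unknown or untested is made for them only; others in the source may bear on it.

Compound 1: `CC(O)(C(=O)Nc1ccc(S(=O)(=O)N2CCCC2)cc1)C(F)(F)F`, 880 nM
Compound 2: `CC(O)(C(=O)Nc1ccc(/C(=N\O)c2ccccc2)cc1)C(F)(F)F`, > 30000 nM
Compound 3: `CCCN(CCC)S(=O)(=O)c1ccc(NC(=O)C(C)(O)C(F)(F)F)cc1`, 6440 nM
Compound 4: `CC(O)(C(=O)Nc1ccc([C@H](O)c2ccccc2)cc1)C(F)(F)F`, not yet measured

Three anilides have been measured in an assay on a protein complex (Cavia porcellus) with sulfonylurea receptors; K-ATP channels (Homo sapiens) as the target; a higher number here means a weaker inhibitor, a lower number a stronger inhibitor. Compound 1 gives 880 nM, the lowest number of the two that are numbers. For the measured compounds named here, compound 3 gives 6440 nM, and the only measured single change, a 7.3-fold higher number from compound 1 to compound 3 (0.86 log units; beyond the scatter), shows that the sulfonyl amine part matters. Compound 2 reaches only (the limit of > 30000 nM in this assay, at which 1 of the 3 values shown sits), a limit and not a number.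

Compound 4 differs from compound 1 by hydroxy(phenyl)methyl in place of (pyrrolidin-1-yl)sulfonyl on an aromatic carbon. Going by the values given here, no measured step covers this change directly. The step from compound 1 to compound 3 only reshapes the amine on the sulfonyl sulfur, whereas here the whole (pyrrolidin-1-yl)sulfonyl is gone. Compound 2, which also carries a phenyl-bearing carbon on that aromatic carbon, sits at a limit, so the nearest comparison points to a large loss in this assay.

Compound 4 is therefore expected to be much weaker than compound 1, with a 23-fold higher number from compound 1 to compound 4 (1.36 log units; beyond the scatter), and an estimated value near 20000 nM, somewhere between 5000 nM and 60000 nM, with a real chance that only a limit is reported.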

Compound 4, half-maximal inhibitory concentration: > 30000 nM
Compound 4 gave a limit, no number; the forecaster's own chance of this, stated with the estimate: 40%; at least 1.5-fold (0.17 log units) between middle value and limit.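

In this assay, the exchange of the whole (pyrrolidin-1-yl)sulfonyl for hydroxy(phenyl)methyl on this aromatic carbon gives an at least 34-fold higher number from compound 1 to compound 4 (1.53 log units; beyond the scatter), a large step, where reshaping only the amine on the sulfonyl sulfur had given a modest one. Compound 4, like compound 2, ends at a limit and not a number: the limit of > 30000 nM in this assay, at which 2 of the 4 values shown sit. Among the compounds shown, only those with a sulfonyl on this carbon, compound 1 and compound 3, give numbers, and both phenyl-bearing groups give none.

The two limits do not allow compound 2 and compound 4 to be ranked against each other. On these data alone, it also remains open whether the loss follows from removing the sulfonyl or adding the phenyl, and whether a carboxylic acid on this carbon, or a piperidine on the sulfonyl sulfur, would give a number.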